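A few compounds are considered here, and "the series" means these few. Any claim that something is new, unique, unknown or untested is made for them only; others in the source may bear on it.

Working notes on the urea sulfonate series.

Among the compounds with values here, compound 2 `O=C(NCCCCl)Nc1ccc(S(=O)(=O)Oc2ccccc2I)cc1` gives 9600 nM in a functional assay on HT-29 cells (Homo sapiens) for antiproliferative activity, read by sulforhodamine B assay, with a stated time of 48 h; on this read-out higher numbers stand for weaker inhibition and lower numbers for stronger inhibition; it holds the highest of the two numbers so far. Its nearest neighbour, compound 1 `CCNC(=O)Nc1ccc(S(=O)(=O)Oc2ccccc2I)cc1`, gives 5300 nM in this assay. Within the data shown here, the only measured step, a 1.8-fold higher number from compound 1 to compound 2 (0.26 log units; within the scatter), is a change on the urea chain and stays within the scatter.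

Compound 3 `O=C(NCC1CCCC1)Nc1ccc(S(=O)(=O)Oc2ccccc2I)cc1` differs from compound 2 by cyclopentyl in place of 2-chloroethyl on a saturated chain carbon bound to an amide-type nitrogen. Among the measured compounds shown here, no measured pair shows a ring replacing a chlorinated chain, so the step from compound 1 to compound 2 bears on it only as a sign that chain edits at this position have so far moved this assay little. On that basis no step beyond the scatter is expected; the estimated step is a 1.4-fold lower number from compound 2 to compound 3 (0.14 log units; within the scatter). Compound 3 is therefore expected to give about 7000 nM in this assay, with a range from 2500 nM to 20000 nM.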

Compound 3, half-maximal inhibitory concentration: 7600 nM
Estimate against measurement, compound 3: 1.1-fold (0.04 log units) below; the measured number falls inside the stated range.
By their numbers in this assay, from the lowest: compounds 1, 3 and 2 (each within the scatter of the next).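

In this assay, within the data shown here, cyclopentyl is the first ring at this place on a saturated chain carbon bound to an amide-type nitrogen, and it gives a 1.3-fold lower number from compound 2 to compound 3 (0.10 log units; within the scatter) and a 1.4-fold higher number from compound 1 to compound 3 (0.16 log units; within the scatter) against the two open-chain compounds. Neither step leaves the scatter, so this position holds the cyclopentyl ring as well as it holds the open chains of compound 1 and compound 2, with no separate effect of the ring or of losing the chlorine to be read here. No measurement shown gives a reason why these three numbers sit so close together.

As far as these compounds go, whether an amine, a carboxylic acid or a much longer chain at this place would move the number beyond the scatter stays open. From the compounds shown here alone, the shared core is constant in all three compounds, so what an edit there would do in this assay also stays open.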